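Fluorine on the benzamide in two thiazole series

The compounds below may be only part of what the source reports. "The series", "measured", "known", "first", "only" and "open" are said of these compounds alone.

Measured compounds:
- compound 1, `CN1CCN(c2ccc(Nc3nc(-c4cccc(NC(=O)c5ccccc5)c4)sc3C(=O)O)cc2)CC1`, 11.9%
- compound 2, `CN1CCN(c2ccc(Nc3nc(-c4cccc(NC(=O)c5ccccc5F)c4)sc3C(=O)O)cc2)CC1`, 86.9%
- compound 3, `CN1CCN(c2ccc(Nc3nc(-c4cccc(NC(=O)c5ccccc5)c4)sc3C(N)=O)cc2)CC1`, 91.3%

All three were tested in a functional assay on Raji cells (Homo sapiens) for antiproliferative activity, read by CCK-8 assay, with a stated time of 72 h, tested at 40 uM; on this read-out higher numbers stand for more inhibition at the one concentration tested (going by the name of the read-out) and lower numbers for less inhibition. Compound 1 gives 11.9% and compound 2 gives 86.9%, a step of a number 75 percentage points higher from compound 1 to compound 2 (beyond the scatter); the change behind it is fluoro in place of hydrogen on an aromatic carbon. Compound 3 gives 91.3%, and the step of a number 79.4 percentage points higher from compound 1 to compound 3 (beyond the scatter) comes from amino in place of hydroxy on a carbonyl carbon, which is also how the core of compound 3 differs from the core of compound 1. Compound 3 and compound 2 lie within the scatter of each other, so no order between them is claimed.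

Compound 4, `CN1CCN(c2ccc(Nc3nc(-c4cccc(NC(=O)c5cccc(F)c5)c4)sc3C(N)=O)cc2)CC1`, has not yet been measured in this assay . It differs from compound 3 by fluoro in place of hydrogen on an aromatic carbon. For the measured compounds named here, this is the same kind of change as the one from compound 1 to compound 2, but not the same: there the fluorine sits ortho to a large group, here it sits meta to a large group. The earlier step was large, but compound 3 already stands near the top of what this read-out can show because of 91.3%, so little room is left for a rise. Compound 4 is therefore expected to stay close to compound 3, with an estimated step of a number 3.3 percentage points lower from compound 3 to compound 4 (within the scatter). The estimate for compound 4 in this assay is 88%, between 70% and 98%.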

Compound 4, a percentage reported as inhibition, at one concentration (the size of the read-out at that concentration, not a potency): 2.78%
Compound 4: middle estimate off by 85.2 percentage points, on the high side; the whole stated range lies above it.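

In this assay, fluoro in place of hydrogen on the benzamide ring now gives a number 88.5 percentage points lower from compound 3 to compound 4 (beyond the scatter), the opposite direction to the rise seen with the same kind of change on the other core. Set side by side, the two steps show that this change has no fixed effect that can simply be carried from one core to the other in this series: the same change on two cores in this assay, a number 75 percentage points higher (beyond the scatter) from compound 1 to compound 2 and a number 88.5 percentage points lower (beyond the scatter) from compound 3 to compound 4, 163.5 percentage points apart, beyond the scatter of two such steps What the steps do not show is why they differ, since two things vary at once: the core has hydroxy or amino on the carbonyl carbon, and the fluorine in compound 4 sits meta to a large group, a different place from the fluorine in compound 2, so the result cannot be assigned to the core, to the fluorine's position, or to the two together.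

The compounds shown leave open what fluoro does on the core of compound 1 when placed as in compound 4, and on the core of compound 3 when placed as in compound 2, the two pairings that would separate core from position. They also leave open whether chloro or methyl at the place of the fluorine in compound 4 would give a similarly low number or a high one.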